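A few compounds are considered here, and "the series" means these few. Any claim that something is new, unique, unknown or untested is made for them only; others in the source may bear on it.

Measured so far in an assay on isolated protein for inhibition of high affinity 3',5'-cyclic-AMP phosphodiesterase 7A (Homo sapiens), read by cAMP accumulation, with a stated time of 10 min; a higher number here means a weaker inhibitor, a lower number a stronger inhibitor:

- compound 1, `COc1nc2c(c(=O)n(C)c(=O)n2C)n1CC(=O)NCc1ccccc1Cl`: > 200000 nM, a limit of this assay
- compound 2, `CCOc1nc2c(c(=O)n(C)c(=O)n2C)n1CC(=O)NCc1ccccc1Cl`: > 200000 nM, a limit of this assay
- compound 3, `CCCOc1nc2c(c(=O)n(C)c(=O)n2C)n1CCCC(=O)Nc1ccc(C(C)(C)C)cc1`: 7760 nM

Compound 1 reaches only a limit in this assay. Compound 2 likewise reaches only a limit. Going by the values given here, compound 3 is the one member of the set with a numerical value. Two of the three results sit at the limit of > 200000 nM in this assay, at which 2 of the 3 values shown sit. Compound 1 and compound 2 differ by hydrogen in place of methyl on a saturated chain carbon bound to an oxygen on an aromatic ring; the step that the two limits leave unreadable from compound 2 to compound 1 cannot be sized, because both ends are limits. The difference between the core of compound 2 and the core of compound 3 is not broken down here.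

Compound 4, `CCCOc1nc2c(c(=O)n(C)c(=O)n2C)n1CCCC(=O)Nc1ccc(C(C)C)cc1`, is not yet measured. It differs from compound 3 by hydrogen in place of methyl on a saturated chain carbon bound to an aromatic carbon and two saturated chain carbons. This is the same kind of change as that from compound 2 to compound 1, though the place differs: there the carbon was bound to an oxygen on an aromatic ring, here it is bound to an aromatic carbon and two saturated chain carbons. No readable step for this kind of change exists in the set, so the expectation rests on compound 3 alone, whose value is 7760 nM. Compound 4 is expected to give about 11000 nM in this assay, within 4000 nM to 35000 nM. This estimate corresponds to an expected step of a 1.4-fold higher number from compound 3 to compound 4 (0.15 log units; within the scatter).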

Compound 4, half-maximal inhibitory concentration: 37600 nM
Compound 4: the middle estimate sits 3.4-fold (0.53 log units) below what was measured, outside the stated range (above it).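

In this assay, the change from tert-butyl to isopropyl, hydrogen in place of methyl on a saturated chain carbon bound to an aromatic carbon and two saturated chain carbons, gives a 4.8-fold higher number from compound 3 to compound 4 (0.69 log units; beyond the scatter). The same kind of change on the core of compound 2, where the carbon is bound to an oxygen on an aromatic ring, cannot be read, because compound 1 and compound 2 both stand at a limit of this assay: the limit of > 200000 nM in this assay, at which 2 of the 4 values shown sit. The series therefore holds one readable instance of this change, on one core and at one place, and it does not show whether that size carries over to another core.

As far as these compounds go, on the core of compound 3, it remains open how the number moves when tert-butyl gives way to another group, such as trifluoromethyl or a carboxylic acid. Also open, from the compounds shown here alone, is how tert-butyl to isopropyl reads on a second core where both values are numbers and not limits.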